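The source may hold more compounds than are shown below. What is called first, only, known or untested is meant among the compounds shown, and "the series" means these compounds.

Compound 1 `CCS(=O)(=O)Nc1cc(-c2ccc3ncnc(Nc4cccc(F)c4)c3c2)cnc1OC` gives 2760 nM in a functional assay on SNU-638 cells (Homo sapiens) for cytotoxicity, read by sulforhodamine B assay, with a stated time of 72 h; on this read-out lower numbers stand for stronger inhibition and higher numbers for weaker inhibition.
Compound 2 `CCS(=O)(=O)Nc1cc(-c2ccc3ncnc(Nc4ccc(F)c(C(=O)OC)c4)c3c2)cnc1OC` gives 2540 nM in this assay.

Compound 2 stands at the lowest of these two numbers, with compound 1 nearest, a difference within the scatter. Compound 3 `CCS(=O)(=O)Nc1cc(-c2ccc3ncnc(Nc4ccc(OC)nc4)c3c2)cnc1OC` is not yet measured; it differs from compound 2 by 6-methoxypyridin-3-yl in place of 4-fluoro-3-(methoxycarbonyl)phenyl on a nitrogen on an aromatic ring. Going by the values given here, the only measured step at this place, a 1.1-fold lower number from compound 1 to compound 2 (0.04 log units; within the scatter), replaced one group on that nitrogen with another and stayed within the scatter. The step expected here is therefore a 1.0-fold lower number from compound 2 to compound 3 (0.01 log units; within the scatter), with no clear direction beyond the scatter. Compound 3 is estimated at 2500 nM, within a range of 1000 nM to 6500 nM.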

Compound 3, half-maximal inhibitory concentration: 4280 nM
Compound 3: the middle estimate sits 1.7-fold (0.23 log units) below what was measured; the range from low to high includes it.
By their numbers in this assay, from the lowest: compounds 2, 1 and 3 (each within the scatter of the next).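

In this assay the 6-methoxypyridin-3-yl group on this nitrogen gives a 1.7-fold higher number from compound 2 to compound 3 (0.23 log units; within the scatter) and a 1.6-fold higher number from compound 1 to compound 3 (0.19 log units; within the scatter) as well. All three aromatic groups at this place, including one whose ring is not carbon only, therefore lie within the scatter of one another, and this read-out does not separate them. Nothing measured here offers a reason for these numbers.

As far as these compounds go, all three groups are six-membered aromatic rings, so it remains open whether a carboxylic acid on the ring, a saturated amine or a longer chain would give a step beyond the scatter.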